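Nitro to Trifluoromethyl: One Change Repeated Across Two Cores

A few compounds are considered here, and "the series" means these few. Any claim that something is new, unique, unknown or untested is made for them only; others in the source may bear on it.

Measured compounds:
Compound 1, `O=[N+]([O-])c1ccc(Sc2ccc(NC(=S)Oc3ccc(O)cc3)cc2)cc1`: 9.21
Compound 2, `Oc1ccc(OC(=S)Nc2ccc(Sc3ccc(C(F)(F)F)cc3)cc2)cc1`: 9.22
Compound 3, `CC(=O)Nc1ccc(OC(=S)Nc2ccc(Oc3ccc([N+](=O)[O-])cc3)cc2)cc1`: 9.04

All three values come from a physicochemical assay for acid dissociation. Compound 2 differs from compound 1 by trifluoromethyl in place of nitro on an aromatic carbon, and this change gives a number 0.01 log units higher from compound 1 to compound 2 (within the scatter). For the measured compounds named here, compound 4, `CC(=O)Nc1ccc(OC(=S)Nc2ccc(Oc3ccc(C(F)(F)F)cc3)cc2)cc1`, is not yet measured; it differs from compound 3 by trifluoromethyl in place of nitro on an aromatic carbon, the same change, at the same kind of place, as the one between compound 1 and compound 2. How the core of compound 3 differs from that of compound 1 is not broken down here; compound 3 stands within the scatter of both compound 1 and compound 2 in this assay.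

Because a number 0.01 log units higher from compound 1 to compound 2 (within the scatter) was within the scatter, the step from compound 3 to compound 4 is expected to be a number 0.01 log units higher from compound 3 to compound 4 (within the scatter) in this assay, of similar size. Compound 4 is therefore estimated to give 9.05 in this assay, expected to fall between 8.8 and 9.3.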

Compound 4, acid dissociation constant: 9.03
For compound 4 the middle estimate is 0.02 log units above the measured one, and the stated range covers the measured number.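

In this assay, trifluoromethyl in place of nitro gave a number 0.01 log units lower from compound 3 to compound 4 (within the scatter), and on the core of compound 1 the same change gave a number 0.01 log units higher from compound 1 to compound 2 (within the scatter), so both steps lie within the scatter. For the compounds shown here, this shows that the change, carried from one core to the other, produced no step distinguishable from the scatter in either pair, but it does not show that the same would hold on any other core or in any other read-out. Nothing shown offers an explanation for this result.

The compounds shown leave open how the step would read if an amine or a carboxylic acid stood in place of nitro. They also leave open whether a longer chain at that carbon would stay within the scatter.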